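Swapping a furan for a phenyl on a nucleoside core

The compounds below may be only part of what the source reports. "The series", "measured", "known", "first", "only" and "open" are said of these compounds alone.

Of the compounds shown here, three of a shared core have been measured in a functional assay on HCT-116 cells (Homo sapiens), read by MTT assay, with a stated time of 72 h; on this read-out lower numbers stand for stronger inhibition and higher numbers for weaker inhibition. Compound 1 `O=c1[nH]cnc2c1c(-c1ccoc1)cn2[C@@H]1O[C@H](CO)[C@@H](O)[C@H]1O` gives 14800 nM in this assay. Compound 3 `Nc1nc2c(c(-c3ccoc3)cn2[C@@H]2O[C@H](CO)[C@@H](O)[C@H]2O)c(=O)[nH]1` gives 17600 nM in this assay. Compound 2 `Nc1nc2c(c(-c3ccco3)cn2[C@@H]2O[C@H](CO)[C@@H](O)[C@H]2O)c(=O)[nH]1` reached only a limit of this assay, > 20000 nM, and that value is a limit rather than a number. Among the two numbers, compound 1 holds the lowest, with compound 3 nearest: the step of a 1.2-fold higher number from compound 1 to compound 3 (0.08 log units; within the scatter) lies within the scatter. The step of an at least 1.1-fold lower number from compound 2 to compound 3 (0.05 log units; that floor lies within the scatter) is also small at its floor.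

Compound 4 `O=c1[nH]cnc2c1c(-c1ccccc1)cn2[C@@H]1O[C@H](CO)[C@@H](O)[C@H]1O` is not yet measured. It differs from compound 1 by phenyl in place of furan-3-yl on an aromatic carbon. Within the data shown here, no measured step changes the same pair of groups; the closest is the exchange of one furan for another between compound 2 and compound 3, which moved little. An exchange of one aromatic group for another at that position is therefore expected to give a step of about a 1.0-fold higher number from compound 1 to compound 4 (0.01 log units; within the scatter), none beyond the scatter. Compound 4 is estimated at 15000 nM in this assay, within 6000 nM to 40000 nM.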

Compound 4, half-maximal inhibitory concentration: > 20000 nM
Compound 4 ended at the assay's limit; the forecaster's own chance of this, stated with the estimate: 30%; middle value at least 1.3-fold (0.12 log units) away from the limit.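

In this assay, compound 4, which carries phenyl in place of furan-3-yl, reaches a limit of the assay and not a number. Going by these compounds, the change reads as an at least 1.3-fold higher number from compound 1 to compound 4 (0.13 log units; that floor lies within the scatter), so only a floor is known and the true size of the step stays unknown. Swapping the five-membered ring for a six-membered aromatic ring of carbon only gives no sign of stronger inhibition at this position, and the upper end of the assay now restricts what can be read from this series: the limit of > 20000 nM in this assay, at which 2 of the 4 values shown sit.

On these data alone, it remains open whether a methyl, an amine or a carboxylic acid on this aromatic carbon would move the number beyond the scatter. Also open, as far as these compounds go, is how phenyl would behave on the core of compound 3, which carries the amino group.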